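Replacing Methoxy with Trifluoromethyl on the Aromatic Ring

The source may hold more compounds than are shown below. What is called first, only, known or untested is meant among the compounds shown, and "the series" means these compounds.

In a functional assay on U-937 cells (Homo sapiens) for antiproliferative activity, read by MTT assay, with a stated time of 72 h (on this read-out lower numbers stand for stronger inhibition and higher numbers for weaker inhibition), compound 1 `Cc1ccc(-c2noc(CCCCCCC(=O)NO)n2)cc1` gives 1360 nM and compound 2 `COc1ccc(-c2noc(CCCCCCC(=O)NO)n2)cc1` gives 3650 nM, the higher of the two numbers. Compound 3 `O=C(CCCCCCc1nc(-c2ccc(C(F)(F)F)cc2)no1)NO` has trifluoromethyl in place of methoxy on an aromatic carbon. Within the data shown here, only one measured step bears on this change: a 2.7-fold higher number from compound 1 to compound 2 (0.43 log units; beyond the scatter), with methoxy in place of methyl, modest but beyond the scatter. Among the measured compounds shown here, no trifluoromethyl compound has been measured, so that step offers only a weak guide, but a modest fall in this assay is expected once methoxy leaves. The expected step is a 2.0-fold lower number from compound 2 to compound 3 (0.31 log units; beyond the scatter). The estimate for compound 3 is 1800 nM, with a range of 700 nM to 4500 nM.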

Compound 3, half-maximal inhibitory concentration: 2870 nM
Estimate against measurement, compound 3: 1.6-fold (0.20 log units) below; low and high end bracket the measured number.
By their numbers in this assay, from the lowest: compound 1; then compounds 3 and 2 (each within the scatter of the next).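

In this assay, trifluoromethyl in place of methoxy gives a 1.3-fold lower number from compound 2 to compound 3 (0.10 log units; within the scatter), so at this position the two groups cannot be told apart. Methyl keeps the lowest number of the three, with trifluoromethyl in its place giving a 2.1-fold higher number from compound 1 to compound 3 (0.32 log units; beyond the scatter), which shows that the gap seen with methoxy is not unique to that group. No measurement here offers a reason for this pattern.

Going by these compounds, whether chlorine, a nitrile or an amine at this position would match or pass methyl stays open. So does the effect of a shorter or longer chain on these groups.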